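The compounds below may be only part of what the source reports. "The series", "measured", "known", "first", "only" and "open" are said of these compounds alone.

Measured so far:
compound 1, `COC(OC)C1=C(C(=O)OC/C=C/c2ccccc2)C(c2cccc(Cl)c2)C(C(=O)O)=C(C)N1`, 3000 nM
compound 2, `COC(OC)C1=C(C(=O)OC/C=C/c2ccccc2)C(c2cccc(Cl)c2)C(C(=O)O)=CN1`, 1100 nM

Both compounds share one core and were tested in an assay on IMR-32 cells for inhibition of Voltage-dependent N-type calcium channel subunit alpha-1B (Homo sapiens), with a stated time of 5 min; on this read-out lower numbers stand for stronger inhibition and higher numbers for weaker inhibition. Compound 1 gives 3000 nM, and compound 2 gives 1100 nM, so compound 2 stands at the lowest of the two numbers. Going by the values given here, the only measured step is a 2.7-fold lower number from compound 1 to compound 2 (0.44 log units; beyond the scatter), hydrogen in place of methyl on a double-bonded ring carbon.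

Compound 3 `COC(OC)C1=C(C(=O)OC/C=C/c2ccccc2)C(c2ccc(Cl)cc2)C(C(=O)O)=CN1` differs from compound 2 by 4-chlorophenyl in place of 3-chlorophenyl on a saturated ring carbon. Among the compounds with values here, no measured step touches the chlorophenyl ring: the step from compound 1 to compound 2 concerns a different place on the core and says nothing about the direction or size of a change on the saturated ring carbon. The data thus give no reason to expect a move beyond the scatter in either direction, and the range of the estimate must be wide. For compound 3 the expected step is a 1.4-fold higher number from compound 2 to compound 3 (0.13 log units; within the scatter), that is, nothing beyond the usual scatter. Compound 3 is therefore estimated at 1500 nM, with a range from 400 nM to 6000 nM.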

Compound 3, half-maximal inhibitory concentration: 1100 nM
Beside the measured number, compound 3's estimate is 1.4-fold (0.13 log units) above it; low and high end bracket the measured number.
By their numbers in this assay, from the lowest: compounds 2 and 3 (each within the scatter of the next); then compound 1.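

In this assay, going by these compounds alone, 4-chlorophenyl in place of 3-chlorophenyl on the saturated ring carbon gives no change at the digits printed from compound 2 to compound 3 (within the scatter) and thus provides the only measured step at this position of the shared core. Among the compounds shown, the chlorine can therefore occupy either of these two places on the phenyl ring without a read-out difference beyond the scatter, whereas the earlier step of a 2.7-fold lower number from compound 1 to compound 2 (0.44 log units; beyond the scatter) at a different place on the core did go beyond it. Nothing measured on these compounds accounts for the two chlorophenyl groups reading alike.

The compounds shown leave open whether the number responds at this position to any larger change, such as an unsubstituted phenyl, a 2-chlorophenyl or a methoxyphenyl group in place of the chlorophenyl ring. They also leave open whether the match between 3-chlorophenyl and 4-chlorophenyl would hold on the core of compound 1, which keeps its methyl group, or with a methyl ester or an amide in place of the carboxy group.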